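The source may hold more compounds than are shown below. What is called first, only, known or untested is meant among the compounds shown, and "the series" means these compounds.

Measured compounds:
Compound 1 `O=Cc1ccc(-c2cn3ccnc3c(-c3ccc4ncn(C5CCCCC5)c4c3)n2)cc1` gives 51.2% in a functional assay on MDA-MB-231 cells (Homo sapiens) for inhibition, read by sulforhodamine B assay, with a stated time of 48 h, tested at 10 uM; a higher number here means more inhibition at the concentration tested (going by the name of the read-out), a lower number less inhibition.
Compound 2 `O=Cc1ccc(-c2cn3ccnc3c(-c3ccc4ncn(Cc5ccccc5)c4c3)n2)cc1` gives 51.2% in this assay.
Compound 3 `c1cn2cc(-c3ccc4c(c3)ncn4C3CCCCC3)nc(-c3ccc4ncn(C5CCCCC5)c4c3)c2n1` gives 28.9% in this assay.

Compound 2 differs from compound 1 only by benzyl in place of cyclohexyl on an aromatic nitrogen; the step of no change at the digits printed from compound 1 to compound 2 (within the scatter) lies within the scatter. Compound 3 rests on a different core; the difference between the two cores is not broken down here. Its number in this assay is the lowest of the three, beyond the scatter from both compound 1 and compound 2.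

Compound 4 `c1ccc(Cn2cnc3ccc(-c4nc(-c5ccc6c(c5)ncn6C5CCCCC5)cn5ccnc45)cc32)cc1` has not yet been measured. It differs from compound 3 by benzyl in place of cyclohexyl on an aromatic nitrogen, the same change as that from compound 1 to compound 2. The step of a number 0.1 percentage points higher from compound 3 to compound 4 (within the scatter) is expected to be small, because no change at the digits printed from compound 1 to compound 2 (within the scatter) showed no change within the scatter. Compound 4 is therefore estimated at 29% in this assay, expected to fall between 15% and 45%.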

Compound 4, a percentage reported as inhibition, at one concentration (the size of the read-out at that concentration, not a potency): -70.1%
Compound 4: the middle estimate sits 99.1 percentage points above what was measured; the whole stated range lies above it.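

Benzyl in place of cyclohexyl on an aromatic nitrogen does not carry from one core to the other in this assay: the same change on two cores in this assay, no change at the digits printed (within the scatter) from compound 1 to compound 2 and a number 99 percentage points lower (beyond the scatter) from compound 3 to compound 4, 99 percentage points apart, beyond the scatter of two such steps

On the core of compound 3 the change gives a number 99 percentage points lower from compound 3 to compound 4 (beyond the scatter), so the level number on the core of compound 1 cannot be read as holding for this swap in general. Two pairs do not show which feature of the cores decides the outcome, nor how the change would behave on a third core.

Open, as far as these compounds go, is how a longer alkyl chain, an amine or a carboxylic acid on that aromatic nitrogen would read on either core. Also open, from the compounds shown here alone, is how compound 4, at -70.1%, would read at other concentrations.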